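The source may report more compounds than this note shows. Statements on the series, on what has been measured and on what is new or still open speak of the compounds shown alone.

The study concerns two measured compounds and one that is yet to be measured. Compound 1 `CC(CCNC(=O)c1c(Cl)cncc1Cl)N1CCC(C(Oc2ccccn2)c2ccc(C(F)(F)F)cc2)CC1` gives 34100 nM in an ADME assay on PBMC cells (Homo sapiens) for cytotoxicity; a higher number here means that more compound is tolerated, a lower number that less compound is tolerated. Among the compounds with values here, compound 2 `Cc1cccc(OC(c2ccc(C(F)(F)F)cc2)C2CCN(C(C)CCNC(=O)c3c(Cl)cncc3Cl)CC2)n1` gives 6700 nM in this assay, which is the lower of the two numbers; its only neighbour is compound 1, and the step between them is a 5.1-fold lower number from compound 1 to compound 2 (0.71 log units; beyond the scatter), a methyl in place of hydrogen on an aromatic carbon. Compound 3 `CC(CCNC(=O)c1c(Cl)cncc1Cl)N1CCC(C(Oc2ccccc2Cl)c2ccc(C(F)(F)F)cc2)CC1` has not been measured yet. It differs from compound 2 by 2-chlorophenyl in place of 6-methylpyridin-2-yl on an oxygen on a saturated carbon. Within the data shown here, no measured step exchanges this ring for another, so nothing measured bears directly on the change; the one step at hand, a 5.1-fold lower number from compound 1 to compound 2 (0.71 log units; beyond the scatter), shows only that a small change at this end of the molecule moved the number by a modest amount, and it gives no direction for the present exchange. For compound 3 the expectation is therefore a step close to none beyond the scatter, a 1.1-fold higher number from compound 2 to compound 3 (0.05 log units; within the scatter), held with wide uncertainty. Compound 3 is thus estimated to give 7500 nM in this assay, within a range from 2500 nM to 25000 nM.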

Compound 3, half-maximal cytotoxic concentration: 4400 nM
Beside the measured number, compound 3's estimate is 1.7-fold (0.23 log units) above it; the range from low to high includes it.
By their numbers in this assay, from the lowest: compounds 3 and 2 (each within the scatter of the next); then compound 1.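

In this assay, the exchange on the oxygen of 6-methylpyridin-2-yl for 2-chlorophenyl gives a 1.5-fold lower number from compound 2 to compound 3 (0.18 log units; within the scatter) and so does not separate these two rings, although one has a ring nitrogen and a methyl group and the other has a carbon-only ring and a chlorine. Measured against the unsubstituted pyridin-2-yl of compound 1, the same place gives a 7.8-fold lower number from compound 1 to compound 3 (0.89 log units; beyond the scatter) in this comparison, a step in the same direction as a 5.1-fold lower number from compound 1 to compound 2 (0.71 log units; beyond the scatter) in the earlier one. Among these three compounds, then, both rings that carry a further group sit on the lower side of compound 1, and none goes against this, while no measurement at hand gives a reason for these numbers.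

On these data alone, compound 3 differs from compound 2 in both the ring atom and the added group at once, so the share of each in the result remains open. Also open, as far as these compounds go, is whether a plain phenyl, a 2-methoxyphenyl or a ring bearing an amine or a carboxylic acid on this oxygen would stay with compound 1 or with compound 2 and compound 3.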